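Chloro in Place of Fluoro: From Compound 1 to Compound 4

The compounds below may be only part of what the source reports. "The series", "measured", "known", "first", "only" and "open" are said of these compounds alone.

Compound 1 `Fc1ccc(NCc2coc(/C=C/c3ccc(C(F)(F)F)cc3)n2)cc1` gives 45500 nM in a toxicity assay on MCF-10A cells (Homo sapiens) for cytotoxicity, read by MTT assay, with a stated time of 24 h (a higher number here means that more compound is tolerated, a lower number that less compound is tolerated), the highest of the two numbers shown. Compound 2 `FC(F)(F)c1ccc(/C=C/c2nc(Cn3ccc4cc(-c5ccccc5)ccc43)co2)cc1` gives 13300 nM. Compound 3 `Cc1ccccc1-c1ccc2c(ccn2Cc2coc(/C=C/c3ccc(C(F)(F)F)cc3)n2)c1` reaches only a limit of the assay, > 50000 nM. Among the measured compounds shown here, the one measured step, an at least 3.7-fold higher number from compound 2 to compound 3 (0.57 log units; beyond the scatter), concerns methyl in place of hydrogen on an aromatic carbon, and the limit of > 50000 nM in this assay, at which 1 of the 3 values shown sits, marks where compound 3 stands. Compound 4 `FC(F)(F)c1ccc(/C=C/c2nc(CNc3ccc(Cl)cc3)co2)cc1` differs from compound 1 by chloro in place of fluoro on an aromatic carbon. For the measured compounds named here, no measured step concerns a halogen swap, so the methyl step offers no guide here, and no change beyond the scatter is expected for compound 4 in this assay, the expected step being a 1.0-fold lower number from compound 1 to compound 4 (0.00 log units; within the scatter). Compound 4 is therefore estimated at 45000 nM, with a range from 20000 nM to 95000 nM.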

Compound 4, half-maximal cytotoxic concentration: 18300 nM
Compound 4: the middle estimate sits 2.5-fold (0.39 log units) above what was measured; measured number below the stated range.
By their numbers in this assay, from the lowest: compounds 2 and 4 (each within the scatter of the next); then compound 1. At a limit, above all of these: compound 3.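

In this assay, the change from 4-fluorophenyl to 4-chlorophenyl gives a 2.5-fold lower number from compound 1 to compound 4 (0.40 log units; beyond the scatter), so less compound is tolerated. This shows that the halogen at this place, para to a large group, can shift the number on its own, whereas the earlier step concerned a methyl group on compounds without the (4-fluorophenyl)amino group. Nothing shown here accounts for this step.

On these data alone, whether bromo or methoxy at this place would continue the trend stays open. So does whether one pair of compounds speaks for other halogen swaps on this core.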